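Working notes on a three-compound comparison

The source may report more compounds than this note shows. Statements on the series, on what has been measured and on what is new or still open speak of the compounds shown alone.

Measured so far:
- compound 1 `Fc1ccc(CSc2nnc(-c3ccncc3)n2-c2ccccc2)cc1`: 12800 nM
- compound 2 `O=C(CSc1nnc(-c2ccncc2)n1-c1ccccc1)N/N=C/c1ccc([N+](=O)[O-])cc1`: 10200 nM

In a functional assay on HCT-116 cells (Homo sapiens) for inhibition, read by MTT assay, with a stated time of 48 h (a lower number here means a stronger inhibitor, a higher number a weaker inhibitor), compound 2 gives 10200 nM, the lower of the two numbers; compound 1 gives 12800 nM, and the gap between the two is within the scatter, so no order can be read from them. Compound 3 `O=C(CSc1nnc(-c2ccncc2)n1-c1ccccc1)N/N=C/c1cccc(F)c1` differs from compound 2 by 3-fluorophenyl in place of 4-nitrophenyl on a carbon with a double bond to nitrogen. For the measured compounds named here, no step between measured compounds covers such an exchange, so nothing beyond the scatter is expected in this assay, in either direction. The step from compound 2 to compound 3 is estimated as a 1.3-fold higher number from compound 2 to compound 3 (0.11 log units; within the scatter). Compound 3 is therefore expected at 13000 nM, with a range from 5000 nM to 35000 nM.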

Compound 3, half-maximal inhibitory concentration: > 50000 nM
Compound 3: a limit, no number; the forecaster's own chance of this, stated with the estimate: 10%; at least 3.8-fold (0.58 log units) between middle value and limit.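

In this assay, the group on the carbon with a double bond to nitrogen matters: 3-fluorophenyl in place of 4-nitrophenyl gives an at least 4.9-fold higher number from compound 2 to compound 3 (0.69 log units; beyond the scatter). Compound 3 gives > 50000 nM, which is a limit and not a number. The true size of the step therefore stays unknown: the limit of > 50000 nM in this assay, at which 1 of the 3 values shown sits.

The exchange alters both the substituent and where it sits on the phenyl, and the compounds shown do not separate the two. As far as these compounds go, how a phenyl carrying an amine or a carboxylic acid would read at this place remains open.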